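The compounds below may be only part of what the source reports. "The series", "measured", "known", "first", "only" and "open" are said of these compounds alone.

Three compounds share one core and differ only in the group carried by the ring nitrogen. In an assay on membranes from Cortex for displacement of a labelled ligand from Sigma non-opioid intracellular receptor 1 (Cavia porcellus), read by scintillation counting, with a stated time of 120 min (on this read-out lower numbers stand for stronger inhibition and higher numbers for weaker inhibition), compound 1 `OC(Cc1ccccc1)CN1CCC(NCCSC(c2ccc(F)cc2)c2ccc(F)cc2)CC1` gives 309 nM, the lowest number of the three, though compound 2 `[O-][S+](CCNC1CCN(CC(O)Cc2ccccc2)CC1)C(c1ccc(F)cc1)c1ccc(F)cc1` sits within the scatter of it with 351 nM. Going by the values given here, compound 3 `O=C(c1ccc(F)cc1)N1CCC(NCC[S+]([O-])C(c2ccc(F)cc2)c2ccc(F)cc2)CC1` gives 1440 nM in this assay, and the change a 4.1-fold higher number from compound 2 to compound 3 (0.61 log units; beyond the scatter) is the one measured step that replaces the same group an acyl group takes over in the new compound.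

Compound 4 `O=C(C1CC1)N1CCC(NCCSC(c2ccc(F)cc2)c2ccc(F)cc2)CC1` differs from compound 1 in one place: cyclopropylcarbonyl in place of 2-hydroxy-3-phenylpropyl on an amine nitrogen in a ring. This is the same kind of exchange, a carbonyl-bearing group in place of the hydroxy-bearing chain, so the step from compound 2 to compound 3 is the guide, and a weakening of comparable size is expected here, because a 4.1-fold higher number from compound 2 to compound 3 (0.61 log units; beyond the scatter) went that way. The estimate for compound 4 in this assay is therefore 1200 nM, within a range from 450 nM to 3500 nM, which means an expected step of a 3.9-fold higher number from compound 1 to compound 4 (0.59 log units; beyond the scatter).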

Compound 4, inhibition constant: 46.4 nM
Estimate against measurement, compound 4: 26-fold (1.41 log units) above, and the stated range ends above it.
By their numbers in this assay, from the lowest: compound 4; then compounds 1 and 2 (each within the scatter of the next); then compound 3.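

In this assay, cyclopropylcarbonyl in place of 2-hydroxy-3-phenylpropyl on the ring nitrogen gives a 6.7-fold lower number from compound 1 to compound 4 (0.82 log units; beyond the scatter), so a carbonyl-bearing group at this position does not by itself weaken inhibition, and the leaving group's phenyl ring and hydroxyl are not required for a low number. The exchange to (4-fluorophenyl)carbonyl went the other way, a 4.1-fold higher number from compound 2 to compound 3 (0.61 log units; beyond the scatter), so the outcome of replacing this chain is not the same in both pairs. Nothing measured here explains that reversal.

On these data alone, the two steps differ both in the entering group and in the sulfur of the core, so which of these matters remains open. Cyclopropylmethyl on the same nitrogen, which keeps the small ring but has no carbonyl, and acetyl, which keeps the carbonyl but has no ring, would help separate those two parts of the entering group.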